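Swapping Amino for Ethyl: Expected Whole-Animal Inhibition

The compounds below may be only part of what the source reports. "The series", "measured", "known", "first", "only" and "open" are said of these compounds alone.

Of the compounds shown here, two have been measured so far; they share one core and differ only in the group on the outer aromatic ring. Compound 1 `O=C(/C=C/C1=Cc2ccccc2OC1)c1ccc([N+](=O)[O-])cc1` carries a nitro group there, and in a functional assay on the whole organism for inhibition, with Mus musculus as the target, with a stated time of 1 h, at a dose of 30 mg/kg by the intraperitoneal route (on this read-out higher numbers stand for more inhibition at the one dose given (going by the name of the read-out) and lower numbers for less inhibition), compound 1 gives 50.8%. Compound 2 `Nc1ccc(C(=O)/C=C/C2=Cc3ccccc3OC2)cc1` carries an amino group instead, and in this assay compound 2 gives 52.6%. The step of a number 1.8 percentage points higher from compound 1 to compound 2 (within the scatter) means that, on these two numbers, compound 2 cannot be told apart from compound 1. Compound 3 `CCc1ccc(C(=O)/C=C/C2=Cc3ccccc3OC2)cc1` has not yet been measured; it differs from compound 2 in one place: ethyl in place of amino on an aromatic carbon. Within the data shown here, the only step at hand, a number 1.8 percentage points higher from compound 1 to compound 2 (within the scatter), is the sole guide, and it suggests that a further exchange at this position may again give no step beyond the scatter. The estimated step is therefore a number 2.6 percentage points lower from compound 2 to compound 3 (within the scatter), and compound 3 is expected to give about 50%, within a likely range from 35% to 65%.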

Compound 3, a percentage reported as inhibition, in the whole organism at one dose (the size of the read-out at that dose, not a potency): 68.1%
For compound 3 the middle estimate is 18.1 percentage points below the measured one, outside the stated range (above it).
By their numbers in this assay, from the lowest: compounds 1 and 2 (each within the scatter of the next); then compound 3.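

In this assay, ethyl in place of amino gives a number 15.5 percentage points higher from compound 2 to compound 3 (beyond the scatter), and ethyl in place of nitro gives a number 17.3 percentage points higher from compound 1 to compound 3 (beyond the scatter). This position looked indifferent while only nitro and amino could be compared, but it does respond to the group placed on it, and compound 3 stands clear of both earlier compounds. Nothing at hand explains why ethyl gives this result.

As far as these compounds go, what remains open is whether this rise belongs to ethyl alone or extends to other carbon groups. Methyl, a longer chain such as propyl, or a branched group such as isopropyl on the same aromatic carbon would show whether the read-out keeps rising, levels off or falls as the carbon group changes.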